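The source may hold more compounds than are shown below. What is called first, only, known or untested is meant among the compounds shown, and "the series" means these compounds.

In a functional assay on U-87MG ATCC cells (Homo sapiens) for cytotoxicity, read by MTT assay, with a stated time of 72 h (on this read-out higher numbers stand for weaker inhibition and lower numbers for stronger inhibition), compound 1 `COc1ccc(-c2cc(C(=O)Nc3ccc(Oc4ccnc5cc(OCCCN6CCCCC6)c(OC)cc45)c(F)c3)c3ccccc3n2)cc1` gives 1360 nM. For the measured compounds named here, that is the higher of the two numbers reported in this assay: compound 2 `COc1cc2c(Oc3ccc(NC(=O)c4cc(-c5cccc(Cl)c5)nc5ccccc45)cc3F)ccnc2cc1OCCCN1CCCCC1` gives 150 nM in this assay, and the step of a 9.1-fold lower number from compound 1 to compound 2 (0.96 log units; beyond the scatter) is the only measured step in this set, lying beyond the scatter. Compound 3 `COc1ccc(-c2cc(C(=O)Nc3ccc(Oc4ccnc5cc(OCCCN6CCC(C)CC6)c(OC)cc45)c(F)c3)c3ccccc3n2)cc1` gives "not determined" (no result reported) in this assay, so no number is available for it. Compound 4 `COc1ccc(-c2cc(C(=O)Nc3ccc(Oc4ccnc5cc(OCCCN6CCCCC6)c(OC)cc45)c(F)c3)c3cc(F)ccc3n2)cc1` differs from compound 1 by fluoro in place of hydrogen on an aromatic carbon; the fluoro sits on a six-membered aromatic ring of carbon only, part of a fused system of two rings, meta to a fused ring and para to a fused ring. Going by the values given here, no measured step touches that ring: the change from compound 1 to compound 2 concerns the aryl group at the other end of the shared core, so it offers no direct guide to the present change. With only a single fluorine entering and nothing else altered, the expected step for compound 4 is a 1.4-fold lower number from compound 1 to compound 4 (0.13 log units; within the scatter), which stays within the scatter. Compound 4 is therefore estimated at 1000 nM, with a range from 350 nM to 3000 nM.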

Compound 4, half-maximal inhibitory concentration: 1100 nM
Estimate against measurement, compound 4: 1.1-fold (0.04 log units) below, and the stated range covers the measured number.
By their numbers in this assay, from the lowest: compound 2; then compounds 4 and 1 (each within the scatter of the next).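

In this assay, fluoro in place of hydrogen on an aromatic carbon gives a 1.2-fold lower number from compound 1 to compound 4 (0.09 log units; within the scatter) and so leaves the number within the scatter of the parent. For the compounds shown here, this is the first reading at this six-membered aromatic ring of carbon only, part of a fused system of two rings, and it shows that a single fluorine at this place, meta to a fused ring and para to a fused ring, brings no change that can be told from repeat scatter, whereas the earlier measured step concerned a different part of the molecule. No evidence at hand bears on why the number stays where it does. The compounds shown leave open whether a larger group at this place, such as methoxy or a dimethylamino group, would also leave the number unchanged. They also leave open whether fluoro would behave the same way with the 3-chlorophenyl group of compound 2.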